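Amino Substitution on Two Nucleoside Cores

The source may report more compounds than this note shows. Statements on the series, on what has been measured and on what is new or still open speak of the compounds shown alone.

Compound 1 `COc1ncnc2c1c(-c1ccsc1)cn2[C@@H]1O[C@H](CO)[C@@H](O)[C@H]1O` was tested in a functional assay on K562 cells (Homo sapiens), read by MTT assay, with a stated time of 72 h (a higher number here means a weaker inhibitor, a lower number a stronger inhibitor), and gives 3450 nM. Compound 2 `COc1nc(N)nc2c1c(-c1ccsc1)cn2[C@@H]1O[C@H](CO)[C@@H](O)[C@H]1O` carries one change relative to it, (amino in place of hydrogen on an aromatic carbon). In this assay compound 2 reaches only the limit of the assay, > 20000 nM. That single change produced an at least 5.7-fold higher number from compound 1 to compound 2 (0.76 log units; beyond the scatter). Compound 3 `O=c1[nH]cnc2c1c(-c1cc3ccccc3o1)cn2[C@@H]1O[C@H](CO)[C@@H](O)[C@H]1O` is built on another core, and the difference between the two cores is not broken down here. In this assay compound 3 likewise reaches only the limit, > 20000 nM. Compound 4 `Nc1nc2c(c(-c3cc4ccccc4o3)cn2[C@@H]2O[C@H](CO)[C@@H](O)[C@H]2O)c(=O)[nH]1` has not yet been measured and differs from compound 3 by amino in place of hydrogen on an aromatic carbon. This is the same kind of change as that between compound 1 and compound 2, though the surroundings are not identical: in compound 1 the entering amino stands meta to a methoxy group (2 heavy atoms), whereas in compound 3 it stands meta to a group of 1 heavy atom. Among the compounds with values here, the one measured instance of the change weakened inhibition beyond the scatter, and compound 3 already sits at the limit, so compound 4 is expected to sit at the limit too. The step is expected to be a step that the limit leaves unreadable from compound 3 to compound 4, in line with an at least 5.7-fold higher number from compound 1 to compound 2 (0.76 log units; beyond the scatter) and with the limit of > 20000 nM in this assay, at which 2 of the 3 values shown sit. For compound 4 the estimated value is 40000 nM, expected between 15000 nM and 120000 nM.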

Compound 4, half-maximal inhibitory concentration: > 20000 nM
Compound 4 was reported as a limit; the forecaster's own chance of this, stated with the estimate: 90%; the middle value does not contradict the limit.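

In this assay compound 4 gives > 20000 nM, which is a limit of the assay and not a number. Compound 3 also stands at a limit, so no step can be read between compound 3 and compound 4: the limit of > 20000 nM in this assay, at which 3 of the 4 values shown sit. The compounds shown leave open whether amino in place of hydrogen changes inhibition at all on the core of compound 3.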